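A few compounds are considered here, and "the series" means these few. Any claim that something is new, unique, unknown or untested is made for them only; others in the source may bear on it.

Measured so far:
- compound 1, `COC(=O)c1ccc(-c2ccc([C@H]3S[C@@H](C)C(=O)Nc4c3c(C)nn4-c3ccccc3C)cc2)cc1`, gives "not active" (no number reported)
- compound 2, `Cc1ccccc1-n1nc(C)c2c1NC(=O)[C@H](C)S[C@@H]2c1ccc(-c2ccc(C(=O)O)cc2)cc1`, gives "not active" (no number reported)
- compound 3, `COc1cccc(Oc2ccc([C@H]3S[C@@H](C)C(=O)Nc4c3c(C)nn4-c3ccccc3C)cc2)c1`, gives 1700 nM

Of the compounds shown here, three sharing one core have been tested in an assay on isolated protein for agonist activity at Bile acid receptor (Homo sapiens), read by AlphaScreen, with a stated time of 30 min; a higher number here means that more compound is needed for the effect, a lower number that less compound is needed. Compound 1 and compound 2 each returned no number at all; they were simply reported as not active, so nothing can be said about how far apart they lie. Among the measured compounds shown here, compound 3 is therefore the only member of the set with a measured half-maximal effective concentration, and it stands alone as the single reference point in this assay.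

The next compound, compound 4, `COc1cccc(-c2ccc([C@H]3S[C@@H](C)C(=O)Nc4c3c(C)nn4-c3ccccc3C)cc2)c1`, differs from compound 3 in one place: 3-methoxyphenyl in place of 3-methoxyphenoxy on an aromatic carbon. The ether oxygen that linked the outer ring to the rest of the molecule is gone, and the outer ring is joined directly to the aromatic carbon.

For the measured compounds named here, with no measured pair of this kind to lean on, the size of the step can only be guessed. Compound 1 and compound 2, which also carry a directly joined outer ring, gave no number, which leans toward a weaker result. Compound 4 is expected to need somewhat more compound than compound 3, a step of a 2.1-fold higher number from compound 3 to compound 4 (0.31 log units; beyond the scatter), probably beyond the usual scatter. The estimate for compound 4 is 3500 nM, with a range from 900 nM to 14000 nM.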

Compound 4, half-maximal effective concentration: 1800 nM
Compound 4: the middle estimate sits 1.9-fold (0.29 log units) above what was measured; low and high end bracket the measured number.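

Swapping 3-methoxyphenoxy for 3-methoxyphenyl, on the aromatic carbon para to a large group, gives a 1.1-fold higher number from compound 3 to compound 4 (0.02 log units; within the scatter) in this assay. Among the compounds shown here, this is the first pair with a number on both sides, and it shows that the ether oxygen linking the outer ring to the rest of the molecule can be removed with no change that this assay can distinguish from ordinary scatter. Nothing available explains why the two compounds read alike, so the result stands as an observation about this one pair only.

From the compounds shown here alone, what remains open is how much the outer ring and its methoxy group contribute, since compound 3 and compound 4 both carry that group and this pair tests only the link. A plain phenyl ring, an amine in place of the methoxy, or a longer chain joining the outer ring to the rest of the molecule would each show whether this position stays as tolerant as this single step suggests.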